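Swapping the Sulfonyl Group on an Amine Nitrogen

The compounds below may be only part of what the source reports. "The series", "measured", "known", "first", "only" and "open" are said of these compounds alone.

In a functional assay on VCaP cells (Homo sapiens) for antiproliferative activity, read by CCK-8 assay, with a stated time of 6 days (on this read-out lower numbers stand for stronger inhibition and higher numbers for weaker inhibition), the compounds here share one core and differ in the group on an amine nitrogen. Compound 1 `C[C@@H](Cn1ccc(-c2ccc(C#N)c(Cl)c2)n1)NC(=O)c1ccccc1` has the entry "not determined" (no result reported), so it offers no number for comparison. Compound 2 `C[C@@H](Cn1ccc(-c2ccc(C#N)c(Cl)c2)n1)NC(=O)c1ccccc1F` gives 2190 nM. Compound 3 `C[C@@H](Cn1ccc(-c2ccc(C#N)c(Cl)c2)n1)NS(=O)(=O)c1cn(C)cn1` gives 13600 nM, the higher of the two available numbers.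

Compound 4 `C[C@@H](Cn1ccc(-c2ccc(C#N)c(Cl)c2)n1)Nc1cccnc1` carries pyridin-3-yl in place of (1-methyl-1H-imidazol-4-yl)sulfonyl on the amine nitrogen (pyridin-3-yl in place of (1-methyl-1H-imidazol-4-yl)sulfonyl on an amine nitrogen). Going by the values given here, the only measured step that bears on this change is a 6.2-fold higher number from compound 2 to compound 3 (0.79 log units; beyond the scatter), where (1-methyl-1H-imidazol-4-yl)sulfonyl replaced (2-fluorophenyl)carbonyl. That modest step shows that the group on this nitrogen can move the number beyond the scatter. Among the compounds with values here, its guidance is indirect, however, since no measured compound carries pyridin-3-yl.

With compound 3 at the top of the measured numbers at 13600 nM, a lower number seems the likelier direction in this assay, although one step cannot settle this. The expected change is a 2.3-fold lower number from compound 3 to compound 4 (0.36 log units; beyond the scatter), smaller than the measured step. For compound 4 the estimated value is 6000 nM, with an expected range from 1500 nM to 20000 nM.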

Compound 4, half-maximal inhibitory concentration: > 30000 nM
Compound 4 gave a limit, no number; the forecaster's own chance of this, stated with the estimate: 15%; middle value at least 5.0-fold (0.69 log units) away from the limit.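

In this assay compound 4 gives > 30000 nM, which is a limit of the assay and not a number. Even so, the direction is clear: putting pyridin-3-yl on the amine nitrogen gives an at least 2.2-fold higher number from compound 3 to compound 4 (0.34 log units; beyond the scatter), and against the carbonyl-linked comparison it gives an at least 13-fold higher number from compound 2 to compound 4 (1.13 log units; beyond the scatter). The earlier compounds compared only a carbonyl link with a sulfonyl link, whereas pyridin-3-yl has neither, and this new kind of group places compound 4 at the weak end of the compounds with a reading, at the top of what the assay can report: the limit of > 30000 nM in this assay, at which 1 of the 4 values shown sits.

The compounds shown leave open whether the weaker result goes with losing the carbonyl or sulfonyl link or with pyridin-3-yl itself, and how far past the limit compound 4 really lies. A pyridin-3-ylcarbonyl group on the same nitrogen would separate these two readings, since it keeps the ring and restores the carbonyl, while a small acetyl group would show how much the carbonyl alone can carry.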